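Cyclohexyl for methyl on the core nitrogen: tolerance expected

This account rests on a few compounds, and the source may have more. Where it says the series, first, only, none or still open, it means among the compounds named here.

Measured compounds:
compound 1, `CCC(=O)Nc1ccc(-c2nc3cc(C(F)(F)F)ccc3n2C2CCCCC2)cc1`, 18000 nM
compound 2, `CC(=O)Nc1ccc(-c2nc3cc(C(F)(F)F)ccc3n2C)cc1`, 46000 nM

Of the compounds shown here, two have been measured in an ADME assay on MDBK cells (Bos taurus) for cytotoxicity, read by MTT assay, with a stated time of 96 h; a lower number here means that less compound is tolerated, a higher number that more compound is tolerated. Compound 2 gives 46000 nM, the highest of the two numbers; its nearest neighbour is compound 1, whose value of 18000 nM lies beyond the scatter below it. Compound 3, `CC(=O)Nc1ccc(-c2nc3cc(C(F)(F)F)ccc3n2C2CCCCC2)cc1`, has not yet been measured.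

Compound 3 follows from compound 2 by the change (cyclohexyl in place of methyl on an aromatic nitrogen). Within the data shown here, no step between measured compounds isolates this change. Compound 1 also carries a cyclohexyl on that aromatic nitrogen and gives the lower number, so the step from compound 2 to compound 3 is expected to move downward by a modest amount, a 2.3-fold lower number from compound 2 to compound 3 (0.36 log units; beyond the scatter), toward the value of compound 1. Compound 3 is therefore expected to give about 20000 nM, within a range from 8000 nM to 50000 nM.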

Compound 3, half-maximal cytotoxic concentration: 17000 nM
Compound 3: middle estimate off by 1.2-fold (0.07 log units), on the high side; measured number inside the range.
By their numbers in this assay, from the lowest: compounds 3 and 1 (each within the scatter of the next); then compound 2.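

In this assay, cyclohexyl in place of methyl on an aromatic nitrogen now has a step of its own, a 2.7-fold lower number from compound 2 to compound 3 (0.43 log units; beyond the scatter), and this step lies beyond the scatter. With cyclohexyl on that nitrogen, hydrogen in place of methyl on a saturated chain carbon bound to a carbonyl carbon gives a 1.1-fold lower number from compound 1 to compound 3 (0.02 log units; within the scatter), which lies within the scatter, so among these compounds only the change on the aromatic nitrogen gives a step that can be read. Nothing given here bears on the reason for either step.

As far as these compounds go, only methyl and cyclohexyl appear on the aromatic nitrogen, so how a cyclopentyl, a phenyl or a longer chain there would read stays open. From the compounds shown here alone, it also stays open whether the chain change would remain within the scatter with methyl on that nitrogen.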